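Methyl for Methoxy on the Amide-Bearing Ring

The source may report more compounds than this note shows. Statements on the series, on what has been measured and on what is new or still open speak of the compounds shown alone.

Compound 2 `COc1ccccc1NC(=O)c1ccc(/N=N\c2c[nH]c3ccccc23)cc1` carries a 2-methoxyphenyl group on the amide-type nitrogen of a shared core that also appears in compound 1 `Cc1ccc(NC(=O)c2ccc(/N=N\c3c[nH]c4ccccc34)cc2)cc1`, where the same nitrogen bears 4-methylphenyl. Among the measured compounds shown here, in a functional assay on HCT-116 cells (Homo sapiens) for inhibition, read by MTT assay, with a stated time of 72 h (on this read-out lower numbers stand for stronger inhibition and higher numbers for weaker inhibition), compound 1 gives 25400 nM, while compound 2 gives 122000 nM, the highest of the two numbers, and the single step between them, a 4.8-fold higher number from compound 1 to compound 2 (0.68 log units; beyond the scatter), sets compound 2 apart from compound 1. Compound 3 `Cc1ccccc1NC(=O)c1ccc(/N=N\c2c[nH]c3ccccc23)cc1` has not been measured in this assay. It differs from compound 2 by methyl in place of methoxy on an aromatic carbon. For the measured compounds named here, no measured pair shows this exact exchange. Going by the values given here, the only step that bears on it is a 4.8-fold higher number from compound 1 to compound 2 (0.68 log units; beyond the scatter), which combined a shift of the substituent along the ring with the change from methyl to methoxy, so its size cannot be divided between those two parts. Since compound 1, with a methyl group, gives 25400 nM, compound 3 is expected to move part of the way back toward that number, a modest decrease of a 2.0-fold lower number from compound 2 to compound 3 (0.31 log units; beyond the scatter). The estimate for compound 3 in this assay is 60000 nM, within a range from 20000 nM to 180000 nM.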

Compound 3, half-maximal inhibitory concentration: 509000 nM
The estimate for compound 3 lay 8.5-fold (0.93 log units) below the measured number; the whole stated range lies below it.
By their numbers in this assay, from the lowest: compound 1; then compound 2; then compound 3.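

In this assay, the exchange of methoxy for methyl on this aromatic carbon, ortho to a large group, can now be read on its own: a 4.2-fold higher number from compound 2 to compound 3 (0.62 log units; beyond the scatter), so methyl at this place carries the number further from compound 1 rather than back toward it. The placement of the methyl group can also be read separately, since 2-methylphenyl in place of 4-methylphenyl gives a 20-fold higher number from compound 1 to compound 3 (1.30 log units; beyond the scatter), a large step beside the modest exchange of groups. The earlier step therefore folded together two parts that run in opposite directions: moving the methyl group raises the number, while methoxy at the new place gives a lower number than methyl does. Nothing measured alongside these numbers bears on the reason for this order.

The compounds shown leave open how methoxy and methyl would compare at the place where compound 1 carries its methyl group. They also leave open whether an amine or a carboxylic acid on this ring would fall within the order seen here.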